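This account rests on a few compounds, and the source may have more. Where it says the series, first, only, none or still open, it means among the compounds named here.

Within the data shown here, the three compounds measured so far share one core and differ only in the group carried by the amide nitrogen. Compound 1 `CNC(=O)c1nc(-c2cccs2)[nH]c(=O)c1O` carries hydrogen there, compound 2 `CC(C)CCNC(=O)c1nc(-c2cccs2)[nH]c(=O)c1O` an isobutyl chain, and compound 3 `CC(=O)NCCNC(=O)c1nc(-c2cccs2)[nH]c(=O)c1O` an acetamidoethyl chain. In an assay on isolated protein for inhibition of Flap endonuclease 1 (Homo sapiens) (a lower number here means a stronger inhibitor, a higher number a weaker inhibitor), compound 1 gives 12000 nM, compound 2 gives 3500 nM, and compound 3 gives 5000 nM. Both chains help: the step of a 3.4-fold lower number from compound 1 to compound 2 (0.54 log units; beyond the scatter) and the step of a 2.4-fold lower number from compound 1 to compound 3 (0.38 log units; beyond the scatter) are modest but beyond the scatter, while the step of a 1.4-fold higher number from compound 2 to compound 3 (0.15 log units; within the scatter) lies within it. Compound 3 therefore has the second highest number of the three, close to compound 2 and clearly apart from compound 1.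

Compound 4 `O=C(Nc1ccc(F)cc1)c1nc(-c2cccs2)[nH]c(=O)c1O` replaces the chain with a ring: 4-fluorophenyl in place of 2-acetamidoethyl on an amide-type nitrogen, that is, 2-acetamidoethyl leaves and 4-fluorophenyl enters on the amide nitrogen whose other neighbour is the carbonyl carbon. Among the measured compounds shown here, no measured step puts a ring on this nitrogen, so only the general lesson applies: substituents there lower the number modestly relative to hydrogen, and two quite different chains land within the scatter of each other. Compound 4 is therefore expected to stay near compound 3, with an expected step of a 1.3-fold lower number from compound 3 to compound 4 (0.10 log units; within the scatter) not beyond the scatter, giving an estimate for compound 4 of 4000 nM with a range from 1300 nM to 12000 nM.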

Compound 4, half-maximal inhibitory concentration: 10500 nM
For compound 4 the middle estimate is 2.6-fold (0.42 log units) below the measured one; the measured number falls inside the stated range.
By their numbers in this assay, from the lowest: compounds 2 and 3 (each within the scatter of the next); then compounds 4 and 1 (each within the scatter of the next).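

In this assay, the amide nitrogen proves not to accept every substituent equally: 4-fluorophenyl there gives a weaker result than either chain, with a 2.1-fold higher number from compound 3 to compound 4 (0.32 log units; beyond the scatter) against 2-acetamidoethyl and a 3.0-fold higher number from compound 2 to compound 4 (0.48 log units; beyond the scatter) against isopentyl, both modest but beyond the scatter. Against methyl, the same ring gives a 1.1-fold lower number from compound 1 to compound 4 (0.06 log units; within the scatter) and so lies within the scatter, which means that the modest gain seen with the two chains does not appear with this ring, and compound 4 goes against any rule that a group larger than methyl on this nitrogen lowers the number. Nothing available explains why this ring and the two chains differ.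

The compounds shown leave open whether the loss belongs to the aromatic ring itself or to its fluorine, and whether an unsubstituted phenyl or a benzyl group, which keeps a saturated carbon on the amide nitrogen, would follow compound 4 or the chains. They also leave open what a chain ending in an amine or a carboxylic acid would do, and whether a longer chain than those in compound 2 and compound 3 would lower the number further.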